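Halogen exchange on the aryl ring of the series

The source may hold more compounds than are shown below. What is called first, only, known or untested is meant among the compounds shown, and "the series" means these compounds.

Measured so far:
compound 1, `COc1ccc(/C=C/C(=O)c2c(C)[n+]([O-])c3ccccc3[n+]2[O-])cc1`, in a functional assay on HSC-2 cells (Homo sapiens) for cytotoxicity, with a stated time of 48 h (on this read-out higher numbers stand for lower toxicity in this test and lower numbers for higher toxicity in this test), gives 20000 nM
compound 2, `Cc1ccc(/C=C/C(=O)c2c(C)[n+]([O-])c3ccccc3[n+]2[O-])cc1`, in this assay gives 8400 nM
compound 3, `Cc1c(C(=O)/C=C/c2ccc(F)cc2)[n+]([O-])c2ccccc2[n+]1[O-]`, in this assay gives 6200 nM

Compound 3 shows the lowest of the three numbers; a 1.4-fold lower number from compound 2 to compound 3 (0.13 log units; within the scatter) lies within the scatter, whereas a 3.2-fold lower number from compound 1 to compound 3 (0.51 log units; beyond the scatter) lies beyond it. Compound 4, `Cc1c(C(=O)/C=C/c2ccc(Br)cc2)[n+]([O-])c2ccccc2[n+]1[O-]`, differs from compound 3 by bromo in place of fluoro on an aromatic carbon. For the measured compounds named here, the steps that bear on this change are those at the same position: a 3.2-fold lower number from compound 1 to compound 3 (0.51 log units; beyond the scatter), modest, and a 1.4-fold lower number from compound 2 to compound 3 (0.13 log units; within the scatter), within the scatter. Going by the values given here, no measured step introduces bromo, so only a small shift in this assay is expected, if any, and it is expected to fall within the scatter. The step of a 1.2-fold lower number from compound 3 to compound 4 (0.09 log units; within the scatter) is therefore expected to be small. Compound 4 is estimated at 5000 nM, with a range from 2500 nM to 12000 nM.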

Compound 4, half-maximal cytotoxic concentration: 19000 nM
Compound 4: the middle estimate sits 3.8-fold (0.58 log units) below what was measured, outside the stated range (above it).
By their numbers in this assay, from the lowest: compounds 3 and 2 (each within the scatter of the next); then compounds 4 and 1 (each within the scatter of the next).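

Bromo in place of fluoro gives a 3.1-fold higher number from compound 3 to compound 4 (0.49 log units; beyond the scatter) in this assay so the two halogens are not interchangeable on this aromatic carbon. Bromo in place of methyl gives a 2.3-fold higher number from compound 2 to compound 4 (0.35 log units; beyond the scatter) and bromo in place of methoxy gives a 1.1-fold lower number from compound 1 to compound 4 (0.02 log units; within the scatter) so compound 4 groups with compound 1 and apart from compounds 2 and 3. Nothing shown accounts for this step.

Going by these compounds, whether chloro or an amine at this place would group with compound 3 or with compound 4 stays open. Also open, on these data alone, is whether the exchange of fluoro for bromo behaves alike on a changed core.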